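Replacing a Sulfonamide Chain with a Lactam-Bearing Piperidine

The compounds below may be only part of what the source reports. "The series", "measured", "known", "first", "only" and "open" are said of these compounds alone.

In a functional assay on CHO-K1 cells for antagonist activity at melanin-concentrating hormone receptor 1 (Homo sapiens), read by inositol phosphate accumulation, with stated times of 10 min and 45 min (on this read-out lower numbers stand for stronger inhibition and higher numbers for weaker inhibition), compound 3 `Cc1nc(NCCCNS(C)(=O)=O)nc2ccc(NC(=O)/C=C/c3ccc(OC(F)(F)F)cc3)cc12` gives 32 nM, the lowest of the three numbers and the most potent measured compound: compound 2 `CCCC1(O)CCN(c2nc(C)c3cc(NC(=O)/C=C/c4ccc(Cl)cc4)ccc3n2)CC1` gives 91 nM and compound 1 `COCCC1(O)CCN(c2nc(C)c3cc(NC(=O)/C=C/c4ccc(Cl)cc4)ccc3n2)CC1` gives 220 nM, both gaps beyond the scatter. Compound 4 `Cc1nc(N2CCC(N3CCCC3=O)CC2)nc2ccc(NC(=O)/C=C/c3ccc(OC(F)(F)F)cc3)cc12` differs from compound 3 by 4-(2-oxopyrrolidin-1-yl)piperidin-1-yl in place of (3-(methanesulfonamido)propyl)amino on an aromatic carbon. For the measured compounds named here, the only measured step, a 2.4-fold lower number from compound 1 to compound 2 (0.38 log units; beyond the scatter), concerns a different part of the molecule, so no step bears directly on this change. Compounds 1 and 2 also carry a different aryl group from compound 3, so their values give no clean guide either. Going by the values given here, with no direct precedent, the step from compound 3 is expected to be a 1.9-fold higher number from compound 3 to compound 4 (0.27 log units; within the scatter), a modest weakening. Compound 4 is estimated at 60 nM, with a range from 15 nM to 250 nM.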

Compound 4, half-maximal inhibitory concentration: 12 nM
For compound 4 the middle estimate is 5.0-fold (0.70 log units) above the measured one; the measured number lies below the stated range.
By their numbers in this assay, from the lowest: compound 4; then compound 3; then compound 2; then compound 1.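

In this assay, the aromatic carbon between two ring nitrogen atoms accepts a very different group, with the change giving a 2.7-fold lower number from compound 3 to compound 4 (0.43 log units; beyond the scatter) in favour of the new group. The open chain, with its sulfonamide and two hydrogen-bond donors, is therefore not required for inhibition, since a two-ring group with no donors gives a lower number. Nothing at hand shows why the number falls.

On these data alone, whether the gain depends on the lactam ring or on the piperidine stays open. A piperidine carrying a plain amine or a carboxylic acid in place of the lactam would help separate the two.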